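The compounds below may be only part of what the source reports. "The series", "measured", "known", "first", "only" and "open" are said of these compounds alone.

Measured compounds: compound 1 `O=C(O)CC/C=C\CC1COC(c2ccc(C(F)(F)F)cc2)OC1c1cccnc1`, 44 nM; compound 2 `CSc1ccc(OC(C)(C)C2OCC(C/C=C\CCC(=O)O)C(c3cccnc3)O2)c([N+](=O)[O-])c1`, 22 nM.

In an assay for inhibition of Thromboxane-A synthase (Homo sapiens), using microsomes (a higher number here means a weaker inhibitor, a lower number a stronger inhibitor), compound 2 gives 22 nM, while compound 1 gives 44 nM; the two numbers lie within the scatter of each other, so neither compound can be called the stronger inhibitor. Compound 3 `CC(C)(Oc1ccccc1Br)C1OCC(C/C=C\CCC(=O)O)C(c2cccnc2)O1` is not yet measured. It differs from compound 2 as follows (a group of 7 heavy atoms (6 carbon, 1 bromine; one six-membered aromatic ring of carbon only) in place of a group of 11 heavy atoms (7 carbon, 1 nitrogen, 2 oxygen, 1 sulfur; one six-membered aromatic ring of carbon only), on an oxygen on a saturated carbon). For the measured compounds named here, with no step between measured compounds to lean on, the change from compound 2 to compound 3 is expected to bring a small shift, if any, probably toward a weaker inhibitor, as a 1.8-fold higher number from compound 2 to compound 3 (0.26 log units; within the scatter). Compound 3 is therefore estimated at 40 nM in this assay, within a range of 12 nM to 130 nM.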

Compound 3, half-maximal inhibitory concentration: 29 nM
For compound 3 the middle estimate is 1.4-fold (0.14 log units) above the measured one, and the stated range covers the measured number.
By their numbers in this assay, from the lowest: compounds 2, 3 and 1 (each within the scatter of the next).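

In this assay, for the compounds shown here, putting 2-bromophenyl on the oxygen on a saturated carbon in place of the group of 11 heavy atoms gives a 1.3-fold higher number from compound 2 to compound 3 (0.12 log units; within the scatter), the only step yet read at this position. At this place, then, a group with 3 hydrogen-bond acceptors and one with none give values within the scatter of each other. No measurement at hand gives a reason for this.

The compounds shown leave open whether this position would tolerate a group without an aromatic ring, such as a plain alkyl chain or an amine.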